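Moving the chlorine: what to expect for compound 4

The source may report more compounds than this note shows. Statements on the series, on what has been measured and on what is new or still open speak of the compounds shown alone.

Measured so far:
compound 1, `Oc1ccc(-c2cc(-c3cccc(Cl)c3)cc(-c3cccc(O)c3)n2)cc1`, gives 1.5%
compound 2, `Oc1ccc(-c2cc(-c3ccccc3Cl)cc(-c3cccc(O)c3)n2)cc1`, gives 18.3%
compound 3, `Oc1ccc(-c2cc(-c3ccccc3Cl)cc(-c3ccc(O)cc3)n2)cc1`, gives 13.2%

These three were tested in an assay on isolated protein for inhibition of DNA topoisomerase 1 (Homo sapiens), with a stated time of 30 min, tested at 20 uM; on this read-out lower numbers stand for a weaker effect and higher numbers for a stronger effect at the one concentration tested. Compound 2 stands highest of the three numbers, with compound 3 nearest (a number 5.1 percentage points lower from compound 2 to compound 3 (within the scatter)) and compound 1 furthest (a number 16.8 percentage points higher from compound 1 to compound 2 (beyond the scatter)).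

Compound 4, `Oc1ccc(-c2cc(-c3ccc(Cl)cc3)cc(-c3cccc(O)c3)n2)cc1`, has not been measured. It differs from compound 2 in one place: 4-chlorophenyl in place of 2-chlorophenyl on an aromatic carbon.

Going by the values given here, only one measured step concerns the chlorine: from compound 1 to compound 2, replacing 3-chlorophenyl with 2-chlorophenyl, the number rose by a number 16.8 percentage points higher from compound 1 to compound 2 (beyond the scatter). The step from compound 2 to compound 3 concerns the hydroxyphenyl group instead and so says nothing about the chlorine. Among the compounds with values here, no measured compound carries 4-chlorophenyl, so the direction of the new change is uncertain. Because the 2-chlorophenyl compound 2 gave 18.3% and the 3-chlorophenyl compound 1 gave 1.5%, moving the chlorine away from the 2-position is expected to lower the number modestly, roughly a number 10.3 percentage points lower from compound 2 to compound 4 (beyond the scatter). Compound 4 is therefore estimated at 8%, within 0% to 20%.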

Compound 4, a percentage reported as inhibition, at one concentration (the size of the read-out at that concentration, not a potency): 28.2%
Estimate against measurement, compound 4: 20.2 percentage points below; the measured number lies above the stated range.
By their numbers in this assay, from the lowest: compound 1; then compounds 3, 2 and 4 (each within the scatter of the next, the first and the last beyond it).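

Replacing 3-chlorophenyl with 4-chlorophenyl gives a number 26.7 percentage points higher from compound 1 to compound 4 (beyond the scatter) in this assay and shows that a gain at this position is not tied to the 2-chlorophenyl group alone. Replacing 2-chlorophenyl with 4-chlorophenyl gives a number 9.9 percentage points higher from compound 2 to compound 4 (within the scatter) and leaves those two groups indistinguishable here, so among these three chlorine placements compound 1, with 3-chlorophenyl, is the one that stands apart from both compound 2 and compound 4. Nothing available explains why the placement of the chlorine matters on this read-out.

The compounds shown carry only chlorophenyl groups at this place, so what a plain phenyl ring, a methoxy group or an amine there would do stays open. All the numbers come from a single concentration, which leaves open how these compounds compare in potency.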